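The compounds below may be only part of what the source reports. "The series", "measured", "known", "first", "only" and "open" are said of these compounds alone.

Compound 1 `COc1ccc(Cn2c(-c3ccccc3)c(-c3ccccc3)c3c(=N)n(CCCO)cnc32)cc1` is one of two members of the series measured so far in an ADME assay on microsomes from liver (Mus musculus, strain CD1) for metabolic stability, read by LC-MS, using NADPH, with a stated time of 60 min; on this read-out lower numbers stand for a shorter-lived compound and higher numbers for a longer-lived compound; in that assay compound 1 gives 0.332 h, the lowest of the two numbers. Compound 2 `N=c1c2c(-c3ccccc3)c(-c3ccccc3)n(Cc3ccccc3)c2ncn1CCNc1ccncc1` gives 0.498 h in this assay, and the gap between compound 1 and compound 2 lies within the scatter, so the two values are not distinguished.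

Compound 3 `COc1ccc(Cn2c(-c3ccccc3)c(-c3ccccc3)c3c(=N)n([C@H]4CC[C@H](O)CC4)cnc32)cc1` has not been measured. It differs from compound 1 by 4-hydroxycyclohexyl in place of 3-hydroxypropyl on an aromatic nitrogen. Going by the values given here, no step between measured compounds bears on this change, and the two measured values say nothing about what a ring in place of a chain at this aromatic nitrogen does to the half-life in this assay. The step is expected to stay within the scatter, with no direction preferred: the expected change is a 1.2-fold higher number from compound 1 to compound 3 (0.08 log units; within the scatter). Compound 3 is estimated at 0.4 h in this assay, with a range from 0.2 h to 0.9 h.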

Compound 3, half-life: 2 h
Estimate against measurement, compound 3: 5.0-fold (0.70 log units) below; the whole stated range lies below it.
By their numbers in this assay, from the lowest: compounds 1 and 2 (each within the scatter of the next); then compound 3.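

In this assay 4-hydroxycyclohexyl in place of 3-hydroxypropyl on this aromatic nitrogen gives a 6.0-fold higher number from compound 1 to compound 3 (0.78 log units; beyond the scatter) and thus shows that the group at this position can shift the half-life beyond the scatter, which the two earlier compounds did not show. Both groups carry one hydrogen-bond donor, one hydrogen-bond acceptor and no net charge, so the step goes with a change in ring, heavy-atom count and stereocentres, and this single pair does not separate those features. No measurement at hand gives a cause for the step.

Cyclohexyl without the hydroxyl, 4-aminocyclohexyl and a longer chain such as 4-hydroxybutyl would separate the contributions of the ring, the hydroxyl and the added carbon atoms. From the compounds shown here alone, the other stereoisomer of 4-hydroxycyclohexyl remains open, as does whether the change carries over to cores other than that of compound 1.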